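Nitro to cyano: an expected gain in growth inhibition

This account rests on a few compounds, and the source may have more. Where it says the series, first, only, none or still open, it means among the compounds named here.

Three compounds have been measured in a functional assay on SK-HEP1 cells (Homo sapiens) for antiproliferative activity, read by sulforhodamine B assay; a higher number here means a weaker inhibitor of growth, a lower number a stronger inhibitor of growth:
compound 1 `COc1ccc2sc(NC(=O)c3ccc(C)cc3)nc2c1`, > 10 ug/mL, a limit of the assay
compound 2 `Cc1cc(C)c2sc(NC(=O)c3ccc(C#N)cc3)nc2c1`, 1.18 ug/mL
compound 3 `COc1ccc2sc(NC(=O)c3ccc([N+](=O)[O-])cc3)nc2c1`, > 10 ug/mL, a limit of the assay

Compound 3 stands at the limit of > 10 ug/mL in this assay, at which 2 of the 3 values shown sit, so its growth inhibition is known only as weaker than that boundary. Within the data shown here, the one measured step that touches it, a step that the two limits leave unreadable from compound 1 to compound 3, runs between two limits and cannot be read. Compound 4 `COc1ccc2sc(NC(=O)c3ccc(C#N)cc3)nc2c1` differs from compound 3 in one place: cyano in place of nitro on an aromatic carbon. Among the measured compounds shown here, no measured step covers this exchange. For the measured compounds named here, the only cyano compound, compound 2, on a different core gives 1.18 ug/mL in this assay, a real number rather than a limit. On that basis compound 4 is expected to give 3.5 ug/mL (range 1 ug/mL to 12 ug/mL). The expected step of an at least 2.8-fold lower number from compound 3 to compound 4 (0.45 log units; beyond the scatter) would be a gain in growth inhibition, though a limit result remains possible.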

Compound 4, concentration for 50% growth inhibition: > 10 ug/mL
Compound 4: only a limit was reported; the forecaster's own chance of this, stated with the estimate: 40%; middle value at least 2.8-fold (0.45 log units) from the limit.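

Compound 1, compound 3 and compound 4 each gave only a limit, not a number, so no step among them can be read: the limit of > 10 ug/mL in this assay, at which 3 of the 4 values shown sit.

As far as these compounds go, whether methyl, nitro and cyano differ at all on their shared core remains open.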